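A few compounds are considered here, and "the series" means these few. Any claim that something is new, unique, unknown or untested is made for them only; others in the source may bear on it.

Measured compounds in a functional assay on MCF7 cells (Homo sapiens) for cytotoxicity, read by MTT assay, with a stated time of 48 h; on this read-out higher numbers stand for weaker inhibition and lower numbers for stronger inhibition:
- Compound 1 `COc1cc(-c2nnc3n2NC(c2ccco2)C(C(=O)c2cccs2)S3)cc(OC)c1OC`; in this assay compound 1 gives > 100000 nM, a limit of the assay rather than a number.
- Compound 2 `COc1cc(-c2nnc3n2NC(c2cccs2)C(C(=O)c2ccc(C)cc2)S3)cc(OC)c1OC`; compound 2 gives 28400 nM.
- Compound 3 `COc1cc(-c2nnc3n2NC(c2cccs2)C(C(=O)c2ccccc2)S3)cc(OC)c1OC`; compound 3 gives > 100000 nM, again a limit rather than a number.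

Compound 1 thus sits at the limit of > 100000 nM in this assay, at which 2 of the 3 values shown sit, so only a range is known for it, and it cannot be ranked against the others. Compound 4 `COc1cc(-c2nnc3n2NC(c2ccco2)C(C(=O)c2ccc(O)cc2)S3)cc(OC)c1OC` differs from compound 1 in one place: 4-hydroxyphenyl in place of thiophen-2-yl on a carbonyl carbon. Within the data shown here, no measured step changes this group. Among the measured compounds shown here, the only measured step, an at least 3.5-fold higher number from compound 2 to compound 3 (0.54 log units; beyond the scatter), is a change of hydrogen in place of methyl on an aromatic carbon, and it shows that a small change on an aromatic ring near the carbonyl can move the number by a modest amount. The direction of an at least 1.6-fold lower number from compound 1 to compound 4 (0.22 log units; that floor lies within the scatter) is expected to be toward a measurable number, but with wide uncertainty. Compound 4 is estimated at 60000 nM, within 15000 nM to 200000 nM.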

Compound 4, half-maximal inhibitory concentration: 88900 nM
Compound 4: the middle estimate sits 1.5-fold (0.17 log units) below what was measured, and the stated range covers the measured number.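

In this assay compound 4 gives 88900 nM, a real number rather than a limit, so a compound with 4-hydroxyphenyl on this carbonyl carbon can be read on the scale of the assay. The change itself reads as an at least 1.1-fold lower number from compound 1 to compound 4 (0.05 log units; that floor lies within the scatter), which means it is a floor and no firm gain can be claimed from it. Compound 1 is held at a limit of the assay, so the true size of the step could be small or large, and the data cannot say which: the limit of > 100000 nM in this assay, at which 2 of the 4 values shown sit.

This change replaces the ring and brings in the hydroxyl at the same time, and the compounds shown do not separate the two. As far as these compounds go, it also remains open how a 4-aminophenyl or 4-methoxyphenyl group on the same carbonyl carbon would read.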